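Swapping a methyl for tert-butyl on a lactone ester

The source may report more compounds than this note shows. Statements on the series, on what has been measured and on what is new or still open speak of the compounds shown alone.

Measured so far:
compound 1 `CC(=O)[C@@]1(C)C(=O)O[C@@H](OC(=O)C(C)(C)C)[C@H]1C` gives 2000 nM
compound 2 `CC(=O)O[C@@H]1OC(=O)[C@@](C)(C(C)=O)[C@@H]1C` gives 12000 nM

Both values come from a functional assay on HT-29 cells (Homo sapiens) for cytotoxicity, read by MTT assay; on this read-out higher numbers stand for weaker inhibition and lower numbers for stronger inhibition. Compound 2 has the higher of the two numbers, and compound 1 sits a clear way below it. Compound 3 `CC(=O)[C@]1(C)C(=O)O[C@@H](OC(=O)C(C)(C)C)[C@H]1C` has not yet been tested; it differs from compound 2 by tert-butyl in place of methyl on a carbonyl carbon. Among the compounds with values here, with no measured step to lean on, the expectation rests on the fact that compound 1, which also carries a tert-butyl, gives 2000 nM. Compound 3 is therefore expected to give 3500 nM, within 1000 nM to 15000 nM, a downward step estimated as a 3.4-fold lower number from compound 2 to compound 3 (0.54 log units; beyond the scatter).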

Compound 3, half-maximal inhibitory concentration: 9000 nM
The estimate for compound 3 lay 2.6-fold (0.41 log units) below the measured number; the range from low to high includes it.
By their numbers in this assay, from the lowest: compound 1; then compounds 3 and 2 (each within the scatter of the next).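

In this assay, tert-butyl in place of methyl on a carbonyl carbon makes no clear difference here: a 1.3-fold lower number from compound 2 to compound 3 (0.12 log units; within the scatter) stays within the usual scatter. The larger gap, a 4.5-fold higher number from compound 1 to compound 3 (0.65 log units; beyond the scatter), shows that a tert-butyl alone does not guarantee the lower number of compound 1. That gap can be traced to the configuration at one saturated ring carbon, and the reason is simple: the fact that compounds 1 and 3 differ only in the configuration as drawn. The compounds shown leave open how a longer chain or an amine would read on that carbonyl carbon, and whether configuration matters as much with such groups.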